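A few compounds are considered here, and "the series" means these few. Any claim that something is new, unique, unknown or untested is made for them only; others in the source may bear on it.

Of the compounds shown here, two sharing one core have so far been measured in an assay on cerebellum for displacement of a labelled ligand from histamine H1 receptor (Cavia porcellus), read by scintillation counting, with a stated time of 60 min; on this read-out higher numbers stand for weaker inhibition and lower numbers for stronger inhibition. Compound 1 `CC1CCN(CCCOc2ccc3c(c2)C(=O)N(C)CC3)CC1` gives 32 nM. Compound 2 `CCN1CCN(CCCOc2ccc3c(c2)C(=O)N(C)CC3)CC1` gives 1100 nM. Of these two numbers, compound 2 stands highest, and the step of a 34-fold higher number from compound 1 to compound 2 (1.54 log units; beyond the scatter) separates it from compound 1. Compound 3 `CN1CCN(CCCOc2ccc3c(c2)C(=O)N(C)CC3)CC1` has not yet been measured. It differs from compound 2 in that (hydrogen in place of methyl on a saturated chain carbon bound to an amine nitrogen in a ring); seen one bond further out, ethyl gives way to methyl, and 4-ethylpiperazin-1-yl becomes 4-methylpiperazin-1-yl. Going by the values given here, no measured step matches this change directly: the only step available, a 34-fold higher number from compound 1 to compound 2 (1.54 log units; beyond the scatter), exchanges a whole 4-methylpiperidin-1-yl ring for 4-ethylpiperazin-1-yl, which is a larger rearrangement than trimming one carbon from the group on the ring nitrogen, so it offers little guidance. In the absence of a bearing step, the expected step is a 1.2-fold lower number from compound 2 to compound 3 (0.09 log units; within the scatter), that is, none clearly beyond the scatter. Compound 3 is therefore estimated at 900 nM in this assay, with a range from 350 nM to 2500 nM.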

Compound 3, inhibition constant: 706 nM
Compound 3: middle estimate off by 1.3-fold (0.11 log units), on the high side; the range from low to high includes it.
By their numbers in this assay, from the lowest: compound 1; then compounds 3 and 2 (each within the scatter of the next).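

In this assay, ethyl and methyl on the 4-ethylpiperazin-1-yl and 4-methylpiperazin-1-yl groups cannot be told apart, since a 1.6-fold lower number from compound 2 to compound 3 (0.19 log units; within the scatter) stays inside the normal spread of repeat measurements. The other new step, a 22-fold higher number from compound 1 to compound 3 (1.34 log units; beyond the scatter), is large and shows that the gap from the 4-methylpiperidin-1-yl compound is not special to the ethyl-bearing group: it appears with the methyl-bearing group as well, so the small trim from ethyl to methyl leaves both compounds far from compound 1. Nothing independent of these binding numbers is available to explain either step.

As far as these compounds go, it remains open whether a hydrogen, or a much larger group such as benzyl, in place of that methyl would separate itself from compound 3 in a way that ethyl and methyl do not. From the compounds shown here alone, it is also open how other rings at the end of the chain, such as morpholin-4-yl or piperidin-1-yl without its methyl, would compare with the 4-methylpiperidin-1-yl group of compound 1.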